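A few compounds are considered here, and "the series" means these few. Any claim that something is new, unique, unknown or untested is made for them only; others in the source may bear on it.

Of the compounds shown here, three sharing one core have been measured in a physicochemical assay for solubility, read by HPLC, in phosphate buffer, measured as kinetic solubility, at pH 7.4; a higher number here means a more soluble compound, a lower number a less soluble compound. Compound 1 `CCC(=O)c1cc(-c2ccc(C)cc2)n(-c2ccc(S(N)(=O)=O)cc2)c1C` gives 1000 nM, and compound 2 `CCOC(=O)c1cc(-c2ccc(C)cc2)n(-c2ccc(S(N)(=O)=O)cc2)c1C` gives 1300 nM. Compound 3 `Cc1c(C(=O)O)cc(-c2ccc(F)cc2)n1-c1ccc(S(N)(=O)=O)cc1` stands highest of the three at 50000 nM, beyond the scatter from both of the others.

Compound 4 `Cc1ccc(-c2cc(C(=O)O)c(C)n2-c2ccc(S(N)(=O)=O)cc2)cc1` has not yet been measured and differs from compound 3 in one place: methyl in place of fluoro on an aromatic carbon. In words, this is methyl in place of fluoro on an aromatic carbon, para to a large group, so 4-fluorophenyl becomes 4-methylphenyl.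

Going by the values given here, no measured pair makes this swap. Among the compounds with values here, the only measured single-place step, a 1.3-fold higher number from compound 1 to compound 2 (0.11 log units; within the scatter), is a different change, ethoxy in place of ethyl on a carbonyl carbon. Compound 1 and compound 2 do carry 4-methylphenyl, but they also differ from compound 3 at the carbonyl carbon, and the data do not split the gap between those two places.

On this thin evidence, no step beyond the scatter is expected, and the estimated move is a 1.6-fold lower number from compound 3 to compound 4 (0.19 log units; within the scatter). The expected lean toward a lower number rests on compound 2, with its 4-methylphenyl group, at 1300 nM. For compound 4 the estimate is 32000 nM, with an expected range of 12000 nM to 60000 nM.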

Compound 4, solubility: 10000 nM
The estimate for compound 4 lay 3.2-fold (0.51 log units) above the measured number, outside the stated range (below it).
By their numbers in this assay, from the lowest: compounds 1 and 2 (each within the scatter of the next); then compound 4; then compound 3.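

In this assay the change from 4-fluorophenyl to 4-methylphenyl, on an aromatic carbon para to a large group, now has a measured size: a 5.0-fold lower number from compound 3 to compound 4 (0.70 log units; beyond the scatter) is beyond the scatter, so this single-atom swap at this position is not silent when hydroxy sits on the carbonyl carbon. With 4-methylphenyl held constant, the carbonyl place can also be read on its own, and both a 7.7-fold higher number from compound 2 to compound 4 (0.89 log units; beyond the scatter) and a 10-fold higher number from compound 1 to compound 4 (1.00 log units; beyond the scatter) lie beyond the scatter, so each of the two places moves the number without help from the other. Nothing in the data shown offers a reason for either of these steps.

As far as these compounds go, how chloro or methoxy in the same aromatic position would compare with fluoro and methyl remains open, as does whether the fluoro-to-methyl swap would move the number by a similar amount with ethyl or ethoxy on the carbonyl carbon. From the compounds shown here alone, it is equally open where an amide or a primary amine at the carbonyl place would fall relative to hydroxy, ethyl and ethoxy.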